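This account rests on a few compounds, and the source may have more. Where it says the series, first, only, none or still open, it means among the compounds named here.

Measured values in an ADME assay on the whole organism for pharmacokinetics, with Mus musculus as the target, at a dose of 10 mg/kg by the oral route (on this read-out higher numbers stand for higher exposure at the dose given and lower numbers for lower exposure), are as follows
- compound 1 `CC/C(=C(/c1ccc(/C=C/C(=O)O)cc1)c1ccc2[nH]ccc2c1)c1ccccc1` gives 9400 ng.h/mL
- compound 2 `CC/C(=C(/c1ccc(/C=C/C(=O)O)cc1)c1ccc2[nH]ncc2c1)c1ccccc1C#N` gives 200 ng.h/mL

Compound 2 has the lower of the two numbers, and its gap to compound 1 lies beyond the usual scatter. Compound 3 `CC/C(=C(/c1ccc(/C=C/C(=O)O)cc1)c1ccc2[nH]ncc2c1)c1ccncc1C` carries 3-methylpyridin-4-yl in place of 2-cyanophenyl on a double-bonded chain carbon bound to a double-bonded chain carbon and a saturated chain carbon. Among the compounds with values here, no measured pair isolates a single change, so this expectation has little direct support. A moderate rise in this assay is expected (estimated step: a 3.0-fold higher number from compound 2 to compound 3 (0.48 log units; beyond the scatter)). The estimate for compound 3 is 600 ng.h/mL (expected range 120 ng.h/mL to 3000 ng.h/mL).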

Compound 3, area under the concentration-time curve: 81 ng.h/mL
The estimate for compound 3 lay 7.4-fold (0.87 log units) above the measured number; measured number below the stated range.
By their numbers in this assay, from the lowest: compound 3; then compound 2; then compound 1.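

Within this assay, replacing 2-cyanophenyl with 3-methylpyridin-4-yl on a double-bonded chain carbon bound to a double-bonded chain carbon and a saturated chain carbon gives a 2.5-fold lower number from compound 2 to compound 3 (0.39 log units; beyond the scatter) and provides the first single-change comparison. The exposure therefore depends on which ring sits at this place, and this pyridine ring does not raise it. As far as these compounds go, whether pyridin-4-yl without the methyl or 2-fluorophenyl would give a different number remains open. No measurement here explains the drop.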